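This account rests on a few compounds, and the source may have more. Where it says the series, first, only, none or still open, it means among the compounds named here.

In a functional assay on MCF7 cells (Homo sapiens) for antiproliferative activity, read by MTT assay, with a stated time of 48 h (on this read-out higher numbers stand for weaker inhibition and lower numbers for stronger inhibition), compound 1 (`CCOc1cc(-c2ccc3cc[nH]c3c2)cn2c(-c3cc(OC)c(OC)c(OC)c3)nnc12`) gives 334 nM. Compound 3 (`COc1cc(-c2nnc3c(OC4CCC4)cc(-c4ccc5[nH]ccc5c4)cn23)cc(OC)c1OC`) gives 267 nM, which lies within the usual scatter of the value for compound 1. Compound 2 (`COc1cc(-c2nnc3c(OC(C)C)cc(-c4ccc5[nH]ccc5c4)cn23)cc(OC)c1OC`) gives the highest number of the three, 1020 nM, and this gap to compound 1 lies beyond the scatter.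

The next compound, compound 4 (`CCOc1cc(-c2ccc3ccn(C)c3c2)cn2c(-c3cc(OC)c(OC)c(OC)c3)nnc12`), alters compound 1 in one place: methyl in place of hydrogen on an aromatic nitrogen. This is methyl in place of hydrogen on an aromatic nitrogen, so that 1H-indol-6-yl becomes 1-methyl-1H-indol-6-yl.

Within the data shown here, only one measured step changes a single place, a 3.8-fold lower number from compound 2 to compound 3 (0.58 log units; beyond the scatter). That step puts cyclobutyl in place of isopropyl on an oxygen on an aromatic ring, so it is a different change at a different place. Among the measured compounds shown here, all three measured compounds carry hydrogen on the nitrogen in question, and the data therefore hold no direct precedent for a methyl there. For the measured compounds named here, that single step shows only that one small change can move the number by a modest amount.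

With no direction to go on, the estimated result in this assay is a 1.1-fold lower number from compound 1 to compound 4 (0.05 log units; within the scatter), which means no expected step beyond the scatter. For compound 4 the estimate is 300 nM, with an expected range from 90 nM to 1000 nM.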

Compound 4, half-maximal inhibitory concentration: 239 nM
Compound 4: middle estimate off by 1.3-fold (0.10 log units), on the high side, within the range that was stated.
By their numbers in this assay, from the lowest: compounds 4, 3 and 1 (each within the scatter of the next); then compound 2.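

The earlier compounds shown here all carried hydrogen on the aromatic nitrogen of the five-membered ring, so they could not show whether that hydrogen matters. In this assay, replacing it with methyl gives a 1.4-fold lower number from compound 1 to compound 4 (0.15 log units; within the scatter), a step within the usual scatter, so the two compounds cannot be told apart on this read-out. For this pair, then, the hydrogen on that nitrogen is not needed to keep the number in the same range, and the nitrogen can carry one added carbon without a measurable loss, although no information at hand explains this result.

This single pair cannot show how much room there is at the nitrogen, since methyl is the only group shown there besides hydrogen, and a larger group such as ethyl, a longer chain such as butyl, or a chain ending in an amine or a carboxylic acid could give a quite different number. On these data alone, it also remains open whether methyl in place of hydrogen would behave the same way when the ethoxy group of compound 1 is replaced by another group on that oxygen.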